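The source may hold more compounds than are shown below. What is called first, only, known or untested is meant among the compounds shown, and "the series" means these compounds.

Measured compounds in a functional assay on KYSE-70 cells for antiproliferative activity against KYSE-70 cell line (Homo sapiens), read by MTT assay, with a stated time of 72 h; on this read-out higher numbers stand for weaker inhibition and lower numbers for stronger inhibition:

- compound 1 `COc1ccc(NC(=O)c2cc(=O)[nH]c3cc(Br)ccc23)cc1`: > 20000 nM.
- compound 2 `O=C(Nc1ccc(C(F)(F)F)cc1)c1cc(=O)[nH]c2cc(Br)ccc12`: > 20000 nM.
- compound 3 `COc1cccc(NC(=O)c2cc(=O)[nH]c3cc(Br)ccc23)c1`: > 20000 nM.

For compound 1 the value > 20000 nM is a limit of this assay, not a number. For compound 2 the value > 20000 nM is likewise a limit. For compound 3 the value > 20000 nM is a limit as well. All three values sit at the limit of > 20000 nM in this assay, at which 3 of the 3 values shown sit, so no ordering among them can be read.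

The change trifluoromethyl in place of methoxy on an aromatic carbon makes the step that the two limits leave unreadable from compound 1 to compound 2, which the two limits leave unreadable. Compound 3 and compound 1 have the same atoms joined differently; the difference between the two cores is not broken down here.

Compound 4 `O=C(Nc1cccc(C(F)(F)F)c1)c1cc(=O)[nH]c2cc(Br)ccc12` is not yet measured. It differs from compound 3 by trifluoromethyl in place of methoxy on an aromatic carbon, the same kind of change as that from compound 1 to compound 2, though here the group stands meta to a large group where before it stood para to a large group. The step from compound 3 to compound 4 is expected to be a step that the limit leaves unreadable from compound 3 to compound 4, beside a step that the two limits leave unreadable from compound 1 to compound 2, resting on the earlier pair sitting at the limit of > 20000 nM in this assay, at which 3 of the 3 values shown sit. Compound 4 is thus expected to give 30000 nM in this assay, most likely again reported only as a limit.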

Compound 4, half-maximal inhibitory concentration: > 20000 nM
Compound 4: a limit, no number; the forecaster's own chance of this, stated with the estimate: 85%; the middle value does not contradict the limit.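

In this assay, compound 4 gives > 20000 nM, which is a limit and not a number. No step can be read from compound 3 to compound 4, as both values are limits: the limit of > 20000 nM in this assay, at which 4 of the 4 values shown sit. The compounds shown leave open whether any change to the shared core gives a readable value in this assay.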